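The source may hold more compounds than are shown below. What is called first, only, known or untested is meant among the compounds shown, and "the series" means these compounds.

Compound 1 `Nc1ccccc1NC(=O)c1ccc(CNCc2nc(-c3ccc(Cl)cc3)no2)cc1` gives 5120 nM
Compound 2 `O=C(NO)c1ccc(CNCc2nc(-c3ccccc3)no2)cc1` gives 14700 nM
Compound 3 `O=C(NO)c1ccc(CNCc2nc(-c3ccc(C(F)(F)F)cc3)no2)cc1` gives 12300 nM

In a functional assay on MDA-MB-231 cells (Homo sapiens) for inhibition, read by MTT assay, with a stated time of 72 h (a lower number here means a stronger inhibitor, a higher number a weaker inhibitor), compound 3 (12300 nM) sits within the scatter of compound 2 (14700 nM), and compound 1 (5120 nM) shows a lower number than either, beyond the scatter. Compound 4 `O=C(NO)c1ccc(CNCc2nc(-c3ccc(Cl)cc3)no2)cc1` differs from compound 3 in one place (chloro in place of trifluoromethyl on an aromatic carbon), with chloro in place of trifluoromethyl on an aromatic carbon. Among the compounds with values here, the one measured step that bears on this swaps hydrogen for trifluoromethyl, a 1.2-fold lower number from compound 2 to compound 3 (0.08 log units; within the scatter) and so gives no sign of a large shift. Compound 1 also carries chloro but differs elsewhere, so it isolates nothing. The expected change is a 1.1-fold lower number from compound 3 to compound 4 (0.05 log units; within the scatter) and thus none beyond the scatter. For compound 4 the estimated value is 11000 nM (expected range 5500 nM to 22000 nM).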

Compound 4, half-maximal inhibitory concentration: 10900 nM
Compound 4: middle estimate off by 1.0-fold (0.00 log units), on the high side; the measured number falls inside the stated range.
By their numbers in this assay, from the lowest: compound 1; then compounds 4, 3 and 2 (each within the scatter of the next).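

In this assay chloro in place of trifluoromethyl on the aromatic carbon gives a 1.1-fold lower number from compound 3 to compound 4 (0.05 log units; within the scatter) and chloro in place of hydrogen gives a 1.3-fold lower number from compound 2 to compound 4 (0.13 log units; within the scatter) so all three groups tested at this position on the hydroxamic-type compounds read alike. With chloro held constant, hydroxy in place of 2-aminophenyl on the amide-type nitrogen gives a 2.1-fold higher number from compound 1 to compound 4 (0.33 log units; beyond the scatter) and so, among these compounds, only the change at that nitrogen moves the number beyond the scatter. No measurement here explains either result. Going by these compounds, whether a methoxy group or an amine on that aromatic carbon would also read alike remains open. So does whether the step at the nitrogen keeps its size with hydrogen or trifluoromethyl on the ring.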